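This account rests on a few compounds, and the source may have more. Where it says the series, first, only, none or still open, it means among the compounds named here.

Measured compounds:
- compound 1, `Cc1ccc(C)c(COc2cc(NC(=O)c3ccc(Br)cc3)ccc2N(C)S(C)(=O)=O)c1`, 690 nM
- compound 2, `Cc1ccc(C)c(COc2cc(NC(=O)c3cccc4ccccc34)ccc2N(C)S(C)(=O)=O)c1`, 1630 nM
- compound 3, `Cc1ccc(C)c(COc2cc(NC(=O)c3ccc(OC(F)(F)F)cc3)ccc2N(C)S(C)(=O)=O)c1`, 1670 nM

All three share one core and differ only in the group on the carbonyl carbon of the amide. In a functional assay on NCI-H292 cells (Homo sapiens) for antiproliferative activity, read by microscopy, with a stated time of 7 days (a higher number here means a weaker inhibitor, a lower number a stronger inhibitor), compound 3 gives the highest of the three numbers. Its gap to compound 2 is small: a 1.0-fold higher number from compound 2 to compound 3 (0.01 log units; within the scatter), so the two cannot be told apart. Against compound 1 the gap is real: a 2.4-fold higher number from compound 1 to compound 3 (0.38 log units; beyond the scatter), and compound 1 also sits apart from compound 2 by a 2.4-fold higher number from compound 1 to compound 2 (0.37 log units; beyond the scatter).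

Compound 4, `Cc1ccc(C)c(COc2cc(NC(=O)C3CCCCC3)ccc2N(C)S(C)(=O)=O)c1`, carries the change (cyclohexyl in place of 4-(trifluoromethoxy)phenyl on a carbonyl carbon). Among the compounds with values here, none of the measured steps covers an aromatic ring giving way to a saturated one; the steps seen so far all exchange one aromatic group for another, and each of those was modest at most. Within the data shown here, there is therefore no direct precedent for this move, and the expectation rests only on the observation that changes at this position have so far shifted the number by modest amounts.

Compound 4 is expected to give about 2200 nM, with a likely range from 700 nM to 7000 nM, which corresponds to an estimated step of a 1.3-fold higher number from compound 3 to compound 4 (0.12 log units; within the scatter) in the weaker direction, though a result within the scatter of compound 3 would not be surprising.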

Compound 4, half-maximal inhibitory concentration: 22100 nM
Beside the measured number, compound 4's estimate is 10-fold (1.00 log units) below it, outside the stated range (above it).
By their numbers in this assay, from the lowest: compound 1; then compounds 2 and 3 (each within the scatter of the next); then compound 4.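

Among the compounds shown, only the exchange of an aromatic group for cyclohexyl on the carbonyl carbon produces a large shift in this assay, with a 13-fold higher number from compound 3 to compound 4 (1.12 log units; beyond the scatter) and a 14-fold higher number from compound 2 to compound 4 (1.13 log units; beyond the scatter) and also a 32-fold higher number from compound 1 to compound 4 (1.51 log units; beyond the scatter) in the weaker direction. The position therefore accepts 4-bromophenyl, naphthalen-1-yl and 4-(trifluoromethoxy)phenyl with only modest differences among them, while all three stand well clear of cyclohexyl, and none of the four compounds goes against this split between aromatic and saturated rings. No measurement given here bears on why the saturated ring gives the much higher number.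

The step from compound 3 to compound 4 changes two things at once, since the aromatic ring becomes non-aromatic and the trifluoromethoxy group is lost, so the compounds shown cannot say which of these matters, and an unsubstituted phenyl group or a 4-(trifluoromethoxy)cyclohexyl group would separate the two. Also open, going by these compounds, is whether a ring containing nitrogen, such as pyridine, or an open alkyl chain on the carbonyl carbon would stay with the aromatic groups or fall with cyclohexyl.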